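This account rests on a few compounds, and the source may have more. Where it says the series, first, only, none or still open, it means among the compounds named here.

Three compounds share one core and differ only in the aryl group on the carbonyl carbon. In a functional assay on SK-OV-3 cells (Homo sapiens) for cytotoxicity, read by MTT assay, with a stated time of 48 h (on this read-out higher numbers stand for weaker inhibition and lower numbers for stronger inhibition), compound 3 `Cc1ccc(C(=O)/C=C/c2ccc3c(c2)B(O)OC3)cc1` gives 3700 nM, the second highest of the three numbers. Compound 2 `O=C(/C=C/c1ccc2c(c1)B(O)OC2)c1ccc(F)cc1` gives 1400 nM in this assay, and compound 1 `O=C(/C=C/c1ccc2c(c1)B(O)OC2)c1ccco1` gives 20700 nM. The steps among them are all beyond the scatter: a 15-fold lower number from compound 1 to compound 2 (1.17 log units; beyond the scatter), a 5.6-fold lower number from compound 1 to compound 3 (0.75 log units; beyond the scatter) and a 2.6-fold higher number from compound 2 to compound 3 (0.42 log units; beyond the scatter). Compound 3 thus sits between the two others, closer to compound 2 than to compound 1.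

Compound 4 `Cc1cccc(C(=O)/C=C/c2ccc3c(c2)B(O)OC3)c1` is the next step. The change is 3-methylphenyl in place of 4-methylphenyl on a carbonyl carbon. Within the data shown here, none of the measured steps moves a substituent around the phenyl ring; the only step that touches the methyl group, from compound 2 to compound 3, swaps it for fluoro and is modest, while the large movement from compound 1 to compound 2 comes from replacing the whole furan ring. Keeping the same atoms and the same ring, the step in this assay is expected to be small, with no clear direction: the expected step is no change at the digits printed from compound 3 to compound 4 (within the scatter), within the scatter. Compound 4 is therefore estimated at 3700 nM, with a range from 1500 nM to 9000 nM.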

Compound 4, half-maximal inhibitory concentration: 2900 nM
For compound 4 the middle estimate is 1.3-fold (0.11 log units) above the measured one; the measured number falls inside the stated range.
By their numbers in this assay, from the lowest: compound 2; then compounds 4 and 3 (each within the scatter of the next); then compound 1.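

In this assay, among these compounds, moving the methyl group gives a 1.3-fold lower number from compound 3 to compound 4 (0.11 log units; within the scatter), the first evidence in this set that 3-methylphenyl and 4-methylphenyl on a carbonyl carbon cannot be told apart on this read-out, at least for this one substituent. The new compound also stands in the same relation to the other two aryl groups as compound 3 does, with a 2.1-fold higher number from compound 2 to compound 4 (0.32 log units; beyond the scatter) and a 7.1-fold lower number from compound 1 to compound 4 (0.85 log units; beyond the scatter), so the 4-fluorophenyl group keeps a small lead over the 3-methylphenyl group and the furan-2-yl group remains well behind it. Nothing available here explains why moving the methyl group leaves the number within the scatter.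

The compounds shown leave open whether the same insensitivity would hold for a fluoro group moved around the ring, since only the methyl group has been moved so far. They also leave open how this carbonyl carbon would respond to a phenyl ring carrying an amine or a carboxylic acid, or to an ethyl group or a longer chain in place of the methyl group.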